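Replacing dimethylamino with (2-hydroxyethyl)amino on a nucleoside core

A few compounds are considered here, and "the series" means these few. Any claim that something is new, unique, unknown or untested is made for them only; others in the source may bear on it.

Of the compounds shown here, three sharing one sugar-bearing core have been measured. Compound 1 `OC[C@H]1OC(n2cnc3c(NCc4ccccc4)nccc32)[C@H](O)[C@@H]1O` carries a benzylamino group on the aromatic carbon and in a functional assay (Homo sapiens) for inhibition of Nucleic Acid, tested at 100 uM (on this read-out higher numbers stand for more inhibition at the one concentration tested (going by the name of the read-out) and lower numbers for less inhibition), compound 1 gives 32%. Compound 2 `OC[C@H]1OC(n2cnc3c(Cl)nccc32)[C@H](O)[C@@H]1O` carries chloro there, and in this assay compound 2 gives 76%. Compound 3 `CN(C)c1nccc2c1ncn2C1O[C@H](CO)[C@@H](O)[C@H]1O` carries dimethylamino, and in this assay compound 3 gives 0%. Compound 3 stands lowest of the three: the change a number 32 percentage points lower from compound 1 to compound 3 (beyond the scatter) and the change a number 76 percentage points lower from compound 2 to compound 3 (beyond the scatter) both lie beyond the scatter.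

Compound 4 `OCCNc1nccc2c1ncn2C1O[C@H](CO)[C@@H](O)[C@H]1O` is not yet measured. It differs from compound 3 by (2-hydroxyethyl)amino in place of dimethylamino on an aromatic carbon.

The two steps that bear on this are those leading into compound 3, because a number 32 percentage points lower from compound 1 to compound 3 (beyond the scatter) shows that swapping benzylamino, an amino group bearing a hydrogen, for dimethylamino lowered the read-out strongly, and a number 76 percentage points lower from compound 2 to compound 3 (beyond the scatter) shows the same direction from chloro. Compound 4 restores an amino group bearing a hydrogen, so the step is expected to run upward by a number 25 percentage points higher from compound 3 to compound 4 (beyond the scatter), though nothing here tells how the hydroxyethyl chain compares with benzyl. In this assay compound 4 is therefore estimated at 25%, with a range from 5% to 50%.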

Compound 4, a percentage reported as inhibition, at one concentration (the size of the read-out at that concentration, not a potency): 0%
The estimate for compound 4 lay 25 percentage points above the measured number; the whole stated range lies above it.
By their numbers in this assay, from the lowest: compounds 3 and 4 (each within the scatter of the next); then compound 1; then compound 2.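

In this assay, the swap of dimethylamino for (2-hydroxyethyl)amino gives no change at the digits printed from compound 3 to compound 4 (within the scatter), so at this position an amino group bearing a hydrogen is not enough on its own to give a read-out above that of compound 3. Within the data shown here, the earlier compounds could not show this, as compound 1 was the only one with such a group. The two larger steps, a number 76 percentage points lower from compound 2 to compound 4 (beyond the scatter) and a number 32 percentage points lower from compound 1 to compound 4 (beyond the scatter), set compound 4 apart from both the chloro and the benzylamino compounds, and the second of these changes only the chain, with hydroxymethyl in place of phenyl, so among these amino groups the read-out follows what the chain carries and not just the hydrogen on the nitrogen.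

From the compounds shown here alone, it remains open whether a plain amino group, a methylamino group, a longer chain ending in phenyl, or bromo in place of chloro would stand nearer compound 1 or compound 2. Nothing among the data shown gives a reason for any of these steps.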